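Compound 2 to compound 3: chloro to bromo

The source may report more compounds than this note shows. Statements on the series, on what has been measured and on what is new or still open speak of the compounds shown alone.

compound 1 `NC(=S)N/N=C(/COc1ccc(Br)cc1)c1ccc(F)cc1`: < 26200 nM, a limit and not a number.
compound 2 `NC(=S)N/N=C(/COc1ccc(Br)cc1)c1ccc(Cl)cc1`: 25100 nM.

Among the measured compounds shown here, in an ADME assay on L929 cells (Mus musculus) for cytotoxicity, read by resazurin assay, with a stated time of 96 h (a lower number here means that less compound is tolerated, a higher number that more compound is tolerated), compound 2 gives 25100 nM, the only actual number so far. The reading for compound 1 is a limit, (the limit of < 26200 nM in this assay, at which 1 of the 2 values shown sits).

Compound 3 `NC(=S)N/N=C(/COc1ccc(Br)cc1)c1ccc(Br)cc1` has bromo in place of chloro on an aromatic carbon, para to a large group: bromo in place of chloro on an aromatic carbon.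

For the measured compounds named here, the one measured step, a step that the limit leaves unreadable from compound 1 to compound 2, is chloro in place of fluoro on an aromatic carbon. Its size cannot be read, so it gives no size to carry over and no direction. No step beyond the scatter is therefore expected in this assay, and the estimate stays anchored on compound 2 at 25100 nM.

For compound 3 the expected value is 24000 nM, with an estimated range of 12500 nM to 45000 nM. The estimate amounts to an expected step of a 1.0-fold lower number from compound 2 to compound 3 (0.02 log units; within the scatter).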

Compound 3, half-maximal cytotoxic concentration: 22600 nM
Compound 3: the middle estimate sits 1.1-fold (0.03 log units) above what was measured; the measured number falls inside the stated range.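

In this assay, among the compounds shown here, the change from 4-chlorophenyl to 4-bromophenyl gives the first readable step at this position (a 1.1-fold lower number from compound 2 to compound 3 (0.05 log units; within the scatter)). For the compounds shown here, for this one pair, exchanging chloro for bromo on the aromatic carbon therefore leaves the reading within the scatter, which is the first size information the series gives for a change at this place. The reading for compound 1 is a limit and not a number, so the steps that start from compound 1 cannot be read: (the limit of < 26200 nM in this assay, at which 1 of the 3 values shown sits).

As far as these compounds go, all three compounds carry a halogen at this position, so the response to an amine, a carboxylic acid or a longer alkyl chain there remains open. From the compounds shown here alone, the effect of replacing the bromo on the other side of the shared core also remains open.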